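Two chlorines on the sulfonamide benzyl group

This account rests on a few compounds, and the source may have more. Where it says the series, first, only, none or still open, it means among the compounds named here.

Compound 2 `O=C1c2ccccc2N(Cc2ccccc2)S(=O)(=O)N1Cc1ccccc1` carries a plain benzyl group on each nitrogen of the shared core. In a functional assay on CCRF-CEM cells (Homo sapiens) for inhibition (on this read-out higher numbers stand for lower toxicity in this test and lower numbers for higher toxicity in this test), compound 2 gives 108000 nM, the lowest of the two plain numbers recorded. Compound 1 `O=C1c2ccccc2N(Cc2cccc(Cl)c2)S(=O)(=O)N1Cc1ccccc1` differs only by a chloro on the benzyl group at the sulfonamide nitrogen, and in this assay compound 1 gives 2100000 nM. Compound 3 `O=C1c2ccccc2N(Cc2ccccc2)S(=O)(=O)N1Cc1ccccc1Cl` instead carries the chloro on the other benzyl group, and for compound 3 the result in this assay is only a limit, > 250000 nM. That result is the limit of > 250000 nM in this assay, at which 1 of the 3 values shown sits.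

Compound 4 `O=C1c2ccccc2N(Cc2ccc(Cl)c(Cl)c2)S(=O)(=O)N1Cc1ccccc1` is reached from compound 2 by one change: 3,4-dichlorophenyl in place of phenyl on a saturated chain carbon bound to a sulfonamide nitrogen in a ring. The measured step that bears on it runs the opposite way: a 19-fold lower number from compound 1 to compound 2 (1.29 log units; beyond the scatter). Removing a chloro from that benzyl group gave a large fall, so placing two chlorines onto the same group is expected to raise the number in this assay by a large step, probably to where compound 1 sits or beyond. For compound 4 the estimated value in this assay is 1500000 nM, with a range from 300000 nM to 6000000 nM. The expected step is a 14-fold higher number from compound 2 to compound 4 (1.14 log units; beyond the scatter).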

Compound 4, half-maximal cytotoxic concentration: 16400 nM
Beside the measured number, compound 4's estimate is 91-fold (1.96 log units) above it, outside the stated range (below it).
By their numbers in this assay, from the lowest: compound 4; then compound 2; then compound 1.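

Within the data shown here, on the benzyl group at the sulfonamide nitrogen, chlorine does not simply raise the number: replacing benzyl with 3,4-dichlorobenzyl gives a 6.6-fold lower number from compound 2 to compound 4 (0.82 log units; beyond the scatter) in this assay, so this change points towards higher toxicity in this test, the opposite direction to the single chloro of compound 1. Adding one more chloro to that already chlorinated benzyl group gives a 130-fold lower number from compound 1 to compound 4 (2.11 log units; beyond the scatter), which shows that the outcome depends strongly on the chlorine pattern on this group. Putting chloro in place of hydrogen therefore has no single effect across these compounds, and the two listed cases even run in opposite directions: the same change on two cores in this assay, an at least 2.3-fold higher number (0.36 log units; beyond the scatter) from compound 2 to compound 3 and a 130-fold lower number (2.11 log units; beyond the scatter) from compound 1 to compound 4, at least 290-fold (2.47 log units) apart, beyond the scatter of two such steps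

The compounds shown leave open how the number responds when this benzyl group carries something other than chlorine, such as a methoxy group, a nitrile or an amine. They also leave open whether 3,4-dichlorobenzyl would lower the number on the other nitrogen, where compound 3 carries a single chloro and its result, > 250000 nM, is a limit.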